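The source may report more compounds than this note shows. Statements on the series, on what has been measured and on what is new or still open speak of the compounds shown alone.

Measured compounds:
compound 1, `CO[C@@H]1[C@H]2OC(=O)C[C@H]2O[C@@H]1C(=O)c1ccccc1` — > 100000 nM
compound 2, `O=C1C[C@H]2O[C@H]([C@H](O)c3ccccc3)[C@H](O)[C@H]2O1` — > 100000 nM
compound 3, `CO[C@@H]1[C@H]2OC(=O)C[C@H]2O[C@@H]1[C@H](O)c1ccccc1` — > 100000 nM

In an ADME assay on MRC5 cells (Homo sapiens) for inhibition, read by MTT assay, with a stated time of 72 h (a higher number here means a weaker inhibitor, a lower number a stronger inhibitor), compound 1 gives > 100000 nM, which is a limit of the assay and not a number. Compound 2 gives > 100000 nM, also a limit. Compound 3 gives > 100000 nM, again a limit. Compound 2 therefore stands at the limit of > 100000 nM in this assay, at which 3 of the 3 values shown sit, and no compound shown is separated from another. Going by the values given here, the only measured step that resembles the change of interest, a step that the two limits leave unreadable from compound 2 to compound 3, has no readable size. Compound 4 is `CO[C@H](c1ccccc1)[C@H]1O[C@@H]2CC(=O)O[C@@H]2[C@H]1O`; compared with compound 2 the change is methyl in place of hydrogen on an oxygen on a saturated carbon. With nothing readable to guide it, the step from compound 2 to compound 4 is expected to be a step that the limit leaves unreadable from compound 2 to compound 4, most likely ending at the limit once more. Compound 4 is estimated at 150000 nM, in the range 50000 nM to 500000 nM.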

Compound 4, half-maximal inhibitory concentration: > 100000 nM
Compound 4 gave a limit, no number (the forecaster's own chance of this, stated with the estimate: 85%); the middle value is on the limit's open side.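

Compound 2 and compound 4 both give only a limit and no number, so the step between them cannot be read: the limit of > 100000 nM in this assay, at which 4 of the 4 values shown sit.

The compounds shown leave open whether methyl in place of hydrogen on an oxygen changes anything in this assay.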